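The compounds below may be only part of what the source reports. "The series", "measured", "known", "first", "only" and "open" are said of these compounds alone.

Measured compounds in a functional assay on BJAB cells (Homo sapiens) for antiproliferative activity, with a stated time of 4 days; a lower number here means that less compound is needed, a higher number that more compound is needed for the effect:
- compound 1, `Cc1ccccc1-c1c(C)nn(-c2nc(-c3ccc(Cl)c(Cl)c3)c(SC(C)C)s2)c1C(=O)O`: 5500 nM
- compound 2, `Cc1nn(-c2nc(-c3ccc(Cl)c(Cl)c3)c(SC(C)C)s2)c(C(=O)O)c1-c1ccncc1`: 5900 nM
- compound 3, `CNc1cc(-c2c(C)nn(-c3nc(-c4ccc(Cl)c(Cl)c4)c(SC(C)C)s3)c2C(=O)O)ccn1`: 18000 nM

Compound 3 gives the highest number of the three in this assay, beyond the scatter from both compound 2 and compound 1. Compound 4, `Cc1nn(-c2nc(-c3ccc(Cl)c(Cl)c3)c(SC(C)C)s2)c(C(=O)O)c1-c1ccc(C(F)(F)F)cc1`, has not been measured. The change from compound 3 to compound 4 is 4-(trifluoromethyl)phenyl in place of 2-(methylamino)pyridin-4-yl on an aromatic carbon. Going by the values given here, the steps that bear on it are a 3.3-fold higher number from compound 1 to compound 3 (0.51 log units; beyond the scatter) and a 3.1-fold higher number from compound 2 to compound 3 (0.48 log units; beyond the scatter), both modest rises upon reaching compound 3; the plain aryl of compound 1 and the pyridin-4-yl of compound 2 gave numbers within the scatter of each other. Another aryl group lacking the methylamino is therefore expected to return to that level, a step of a 3.0-fold lower number from compound 3 to compound 4 (0.48 log units; beyond the scatter). Compound 4 is expected to give about 6000 nM, in the range 2500 nM to 15000 nM.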

Compound 4, half-maximal effective concentration: 3500 nM
Beside the measured number, compound 4's estimate is 1.7-fold (0.23 log units) above it; the range from low to high includes it.
By their numbers in this assay, from the lowest: compounds 4, 1 and 2 (each within the scatter of the next); then compound 3.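

In this assay, a 5.1-fold lower number from compound 3 to compound 4 (0.71 log units; beyond the scatter) shows that the rise seen with the 2-(methylamino)pyridin-4-yl group does not carry over to a 4-(trifluoromethyl)phenyl group at this position. With a 1.7-fold lower number from compound 2 to compound 4 (0.23 log units; within the scatter) and a 1.6-fold lower number from compound 1 to compound 4 (0.20 log units; within the scatter), three different aryl groups now lie within the scatter, and only compound 3 stands apart from them. Nothing available here explains this difference. As far as these compounds go, it remains open whether a plain amino group or a morpholine on the pyridin-4-yl ring would give the same rise. From the compounds shown here alone, it is equally open whether a methylamino group on a carbon-only ring would do so.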